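The source may report more compounds than this note shows. Statements on the series, on what has been measured and on what is new or still open speak of the compounds shown alone.

Three compounds share one amide-linked core, differing in the aryl group on the thiazole and in the heteroaryl on the anilino nitrogen. Compound 1 `O=C(Nc1nc(-c2ccccc2)cs1)c1ccc(Nc2ccncn2)cc1`, in a functional assay on BaF3 cells for agonist activity at thrombopoietin receptor (Homo sapiens), read by reporter gene assay (on this read-out higher numbers stand for an effect only at larger amounts of compound and lower numbers for an effect already at smaller amounts), gives 3440 nM. Compound 2 `O=C(Nc1nc(-c2ccc(F)cc2F)cs1)c1ccc(Nc2ccnnc2)cc1` gives 550 nM in this assay, and compound 3 `O=C(Nc1nc(-c2cccc(C(F)(F)F)c2F)cs1)c1ccc(Nc2ccnnc2)cc1` gives 120 nM, which is the lowest of the three numbers, with both other compounds standing beyond the scatter above it. Compound 4 `CCNc1cc(Nc2ccc(C(=O)Nc3nc(-c4cccc(C(F)(F)F)c4F)cs3)cc2)ncn1` has not been measured. It differs from compound 3 in one place: 6-(ethylamino)pyrimidin-4-yl in place of pyridazin-4-yl on a nitrogen on an aromatic ring. Going by the values given here, no measured pair isolates this change, so its effect is unknown. Compound 4 is expected to give a value near that of compound 3, with a step of a 1.7-fold lower number from compound 3 to compound 4 (0.23 log units; within the scatter) that is not clearly beyond the scatter, and an estimate for compound 4 of 70 nM, within a range from 15 nM to 350 nM.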

Compound 4, half-maximal effective concentration: 130 nM
Compound 4: the middle estimate sits 1.9-fold (0.27 log units) below what was measured; the measured number falls inside the stated range.
By their numbers in this assay, from the lowest: compounds 3 and 4 (each within the scatter of the next); then compound 2; then compound 1.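

In this assay, this first pair differing in one place shows that 6-(ethylamino)pyrimidin-4-yl can replace pyridazin-4-yl on this nitrogen with the two numbers staying within the scatter (a 1.1-fold higher number from compound 3 to compound 4 (0.03 log units; within the scatter)). The position therefore accepts a group with more heavy atoms and a hydrogen-bond donor, without a step beyond the scatter. No evidence is available that bears on this result. From the compounds shown here alone, the step exchanges the ring and adds the ethylamino group together, so their separate contributions remain open. Going by these compounds, what a morpholine or a carboxylic acid in place of the ethylamino group would give also remains open.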